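The source may report more compounds than this note shows. Statements on the series, on what has been measured and on what is new or still open speak of the compounds shown alone.

Measured so far in a functional assay on MCF7 cells (Homo sapiens) for inhibition, read by MTT assay, with a stated time of 72 h; a lower number here means a stronger inhibitor, a higher number a weaker inhibitor:
- compound 1 `COc1cc(NC(C)CCCNC(=O)Nc2cccc(F)c2)c2ncccc2c1`: 18000 nM
- compound 2 `COc1cc(NC(C)CCCNC(=O)Nc2ccc(Cl)cc2)c2ncccc2c1`: 12000 nM
- compound 3 `COc1cc(NC(C)CCCNC(=O)NNC(=O)Nc2cccc(Cl)c2)c2ncccc2c1`: 220 nM

Compound 3 holds the lowest of the three numbers, and its steps to both other compounds lie beyond the scatter. The next structure is compound 4 `COc1cc(NC(C)CCCNC(=O)Nc2ccc(O)cc2)c2ncccc2c1`, with the change (4-hydroxyphenyl in place of ((3-chlorophenyl)carbamoyl)amino on an amide-type nitrogen). This puts an aryl ring directly on the amide-type nitrogen, as in compound 1 and compound 2.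

Among the measured compounds shown here, two measured steps bear on this change, and both are large: an 82-fold lower number from compound 1 to compound 3 (1.91 log units; beyond the scatter) and a 55-fold lower number from compound 2 to compound 3 (1.74 log units; beyond the scatter). Compound 4 runs in the opposite direction, towards a higher number. For the measured compounds named here, the swap of aryl groups in a 1.5-fold lower number from compound 1 to compound 2 (0.18 log units; within the scatter) moved the value only within the scatter, though no measured compound carries 4-hydroxyphenyl. A large step of similar size is therefore expected in this assay, leading to a weaker inhibitor. The expected change is a 64-fold higher number from compound 3 to compound 4 (1.80 log units; beyond the scatter). For compound 4 the estimated value is 14000 nM, with an expected range of 5000 nM to 40000 nM.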

Compound 4, half-maximal inhibitory concentration: 5200 nM
For compound 4 the middle estimate is 2.7-fold (0.43 log units) above the measured one; measured number inside the range.
By their numbers in this assay, from the lowest: compound 3; then compound 4; then compounds 2 and 1 (each within the scatter of the next).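

With an aryl ring placed directly on the amide-type nitrogen, compound 4 does not keep the low number of the longer ((3-chlorophenyl)carbamoyl)amino group, with a 24-fold higher number from compound 3 to compound 4 (1.37 log units; beyond the scatter) in this assay. The aryl substituent still matters at this place: hydroxy in place of chloro gives a 2.3-fold lower number from compound 2 to compound 4 (0.36 log units; beyond the scatter), and 4-hydroxyphenyl in place of 3-fluorophenyl gives a 3.5-fold lower number from compound 1 to compound 4 (0.54 log units; beyond the scatter), whereas the earlier aryl swap stayed within the scatter. No supporting data on hand bear on the reason for these shifts.

The compounds shown leave open whether a 4-aminophenyl or 4-carboxyphenyl group on the amide-type nitrogen would follow 4-hydroxyphenyl. They also leave open whether a hydroxy group on the ring of the longer ((3-chlorophenyl)carbamoyl)amino group, in place of its chloro, would shift the value in the same way.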